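Swapping the aryl amine on a diaryl urea core

A few compounds are considered here, and "the series" means these few. Any claim that something is new, unique, unknown or untested is made for them only; others in the source may bear on it.

Compound 1 `COc1cc(NC(=O)Nc2cc(Nc3ccc(C)c(C)c3)ncn2)cc(OC)c1`: 66%
Compound 2 `CCc1ccc(Nc2cc(NC(=O)Nc3c(Cl)cccc3Cl)ncn2)cc1`: 70.1%

Of the compounds shown here, two have been measured in a functional assay on PC-9 cells (Homo sapiens) for inhibition, read by MTT assay, with a stated time of 48 h, tested at 10 uM; on this read-out lower numbers stand for less inhibition and higher numbers for more inhibition at the one concentration tested (going by the name of the read-out). Compound 1 gives 66% and compound 2 gives 70.1%. The two values sit within the usual scatter of one another, so neither compound can be set above the other on this read-out; compound 1 simply stands alongside compound 2. Within the data shown here, no step between two measured compounds that differ in a single place is available, and compound 1 and compound 2 differ at more than one place, so their two values show only that both inhibit to a similar degree at the single concentration tested.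

Compound 3 `COc1cc(NC(=O)Nc2cc(Nc3ccc(OC)c(I)c3)ncn2)cc(OC)c1` has not yet been measured. It departs from compound 1 in one place: 3-iodo-4-methoxyphenyl in place of 3,4-dimethylphenyl on a nitrogen on an aromatic ring. Without any single-point step to lean on, the step of a number 1 percentage points lower from compound 1 to compound 3 (within the scatter) is expected to stay within the scatter, in no particular direction. On that basis compound 3 is estimated at 65%, with a range from 45% to 85%.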

Compound 3, a percentage reported as inhibition, at one concentration (the size of the read-out at that concentration, not a potency): 47.1%
Compound 3: middle estimate off by 17.9 percentage points, on the high side, and the stated range covers the measured number.
By their numbers in this assay, from the lowest: compound 3; then compounds 1 and 2 (each within the scatter of the next).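

In this assay, among these compounds, 3-iodo-4-methoxyphenyl in place of 3,4-dimethylphenyl on a nitrogen on an aromatic ring gives a number 18.9 percentage points lower from compound 1 to compound 3 (beyond the scatter), the first comparison that isolates a single place. Compound 1 and compound 2 differ at more than one place and could show only similar inhibition at the one concentration tested, whereas this pair shows that inhibition in these cells responds to the group at this position, with the rest of compound 1 held constant. No measurement is available to explain the lower inhibition seen with the new group.

The iodine and the methoxy enter together and both methyl groups leave, so the compounds shown leave open which part of the change goes with the step; a 3-iodo-4-methylphenyl or a 4-methoxy-3-methylphenyl group at the same place would separate the two. They also leave open whether 3-iodo-4-methoxyphenyl would give a similar step on the rest of compound 2, which differs from compound 1 at more than one place.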